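The source may report more compounds than this note shows. Statements on the series, on what has been measured and on what is new or still open speak of the compounds shown alone.

Of the compounds shown here, three built on one shared core have been measured in a functional assay on MDA-MB-231 cells (Homo sapiens) for cytotoxicity, read by MTT assay, with a stated time of 68 h; on this read-out higher numbers stand for weaker inhibition and lower numbers for stronger inhibition. Compound 1 `O=C(/C=C/c1cccc(OCc2ccccc2)c1)c1cccc(Br)c1` gives 6900 nM, compound 2 `O=C(/C=C/c1cccc(OCc2ccccc2)c1)c1ccc(Cl)cc1Cl` gives 6800 nM, and compound 3 `O=C(/C=C/c1cccc(OCc2ccccc2)c1)c1ccccc1` gives 20000 nM. Compound 3 thus stands at the highest of the three numbers in this assay: the step of a 2.9-fold higher number from compound 1 to compound 3 (0.46 log units; beyond the scatter) and the step of a 2.9-fold higher number from compound 2 to compound 3 (0.47 log units; beyond the scatter) both lie beyond the scatter, so compound 3 is the weakest inhibitor among those measured.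

Compound 4 `O=C(/C=C/c1cccc(OCc2ccccc2)c1)c1ccc(Cl)cc1` has not yet been measured. Relative to compound 3 it carries chloro in place of hydrogen on an aromatic carbon, on the ring attached to the carbonyl carbon. Among the compounds with values here, two measured steps bear on this change. The step of a 2.9-fold higher number from compound 1 to compound 3 (0.46 log units; beyond the scatter) put hydrogen in place of bromo on that ring, and the step of a 2.9-fold higher number from compound 2 to compound 3 (0.47 log units; beyond the scatter) put phenyl in place of 2,4-dichlorophenyl; both raised the number by a modest, similar amount. Restoring a single chloro to that ring is therefore expected to move the number back in the opposite direction by a modest step, a 2.7-fold lower number from compound 3 to compound 4 (0.43 log units; beyond the scatter). The halogen pattern of compound 4 matches neither compound 1 nor compound 2, so the expectation carries some uncertainty. Compound 4 is expected to give 7500 nM in this assay, with a range from 3500 nM to 16000 nM.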

Compound 4, half-maximal inhibitory concentration: 21500 nM
Estimate against measurement, compound 4: 2.9-fold (0.46 log units) below; measured number above the stated range.
By their numbers in this assay, from the lowest: compounds 2 and 1 (each within the scatter of the next); then compounds 3 and 4 (each within the scatter of the next).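

In this assay, the step of a 1.1-fold higher number from compound 3 to compound 4 (0.03 log units; within the scatter) shows that a chloro para to a large group, the change from phenyl to 4-chlorophenyl, does not on its own shift the number, so a halogen on this ring is not enough to give the lower values seen earlier. The second chloro of the 2,4-dichlorophenyl ring does go with a change, as removing it gives a 3.2-fold higher number from compound 2 to compound 4 (0.50 log units; beyond the scatter), and exchanging the 3-bromophenyl ring for 4-chlorophenyl gives a 3.1-fold higher number from compound 1 to compound 4 (0.49 log units; beyond the scatter), so among these compounds the number depends on the halogen pattern and not merely on a halogen being present. No measurement at hand accounts for this difference between the halogen patterns.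

The compounds shown do not separate the effect of where a halogen sits from that of the kind of halogen or the number of halogens, since compound 1 differs from compound 4 in both the halogen and its place. They also leave open whether a bromo, a methoxy group or an amine in place of the chloro of compound 4 would give a number different from that of compound 3.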